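Methoxy Enters the Anilino Ring of Compound 1

A few compounds are considered here, and "the series" means these few. Any claim that something is new, unique, unknown or untested is made for them only; others in the source may bear on it.

Compound 1 `Cc1nc(SCC(=O)Nc2nc(-c3ccc(Cl)cc3)cs2)n(Nc2ccccc2)c1C` is one of two compounds that have been measured in a functional assay on SN12C cells (Homo sapiens) for antiproliferative activity, read by sulforhodamine B assay, with a stated time of 48 h; a lower number here means that less compound is tolerated, a higher number that more compound is tolerated. In this assay compound 1 gives 35800 nM, the lowest of the two numbers, while compound 2 `Cc1ccc(Nn2c(SCC(=O)Nc3nc(-c4ccccc4)cs3)nc(C)c2C)cc1` gives 63000 nM; the two values lie within the scatter of each other, so neither is set apart from the other. Compound 3 `COc1ccc(Nn2c(SCC(=O)Nc3nc(-c4ccc(Cl)cc4)cs3)nc(C)c2C)cc1` has not yet been measured. It is reached from compound 1 by the change (methoxy in place of hydrogen on an aromatic carbon), that is, methoxy in place of hydrogen on an aromatic carbon. Among the compounds with values here, no step between measured compounds isolates this change, and compounds 1 and 2 differ in more than one place, so the two values show nothing about it on their own. Compound 3 is expected to give a number close to that of compound 1, with the step from compound 1 to compound 3 estimated at a 1.1-fold higher number from compound 1 to compound 3 (0.05 log units; within the scatter), no further than the scatter in either direction. The expected value for compound 3 is 40000 nM, within a range from 15000 nM to 100000 nM.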

Compound 3, concentration lethal to 50% of the cells: > 100000 nM
Compound 3 ended at the assay's limit; the forecaster's own chance of this, stated with the estimate: 10%; middle value at least 2.5-fold (0.39 log units) from the limit.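

In this assay, the change from anilino to (4-methoxyphenyl)amino gives an at least 2.7-fold higher number from compound 1 to compound 3 (0.44 log units; beyond the scatter), which shows that this position on the core of compound 1 is not indifferent to substitution, and that more compound is tolerated once methoxy stands there. Compound 3 gives > 100000 nM, which is a limit of the assay and not a number. The step is therefore only a lower bound, and its full size stays unknown: the limit of > 100000 nM in this assay, at which 1 of the 3 values shown sits.

The compounds shown leave open whether a hydroxyl, an amine or an ethoxy group on the same carbon would move the number in the same direction. They also leave open whether methoxy would give a similar step on a core that carries a phenyl in place of the 4-chlorophenyl of compound 1.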